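The source may report more compounds than this note shows. Statements on the series, on what has been measured and on what is new or still open speak of the compounds shown alone.

In a functional assay on HeLa cells (Homo sapiens) for inhibition, read by CCK-8 assay, with a stated time of 48 h (a lower number here means a stronger inhibitor, a higher number a weaker inhibitor), the measured compounds are:

compound 1 `COc1cc(-c2ccnc3cc(-c4ccc(F)cc4)nn23)cc(OC)c1OC` with 5840 nM
compound 2 `COc1cc(-c2ccnc3cc(-c4c[nH]c5ccccc45)nn23)cc(OC)c1OC` with 195 nM
compound 3 `Cn1ccc2cc(-c3cc4nccc(-c5ccc(F)cc5)n4n3)ccc21` with 5210 nM

Compound 1 lies at the high end of these numbers, within the scatter of compound 3 and far above compound 2. Compound 4 `COc1cc(-c2ccnc3cc(-c4ccccc4)nn23)cc(OC)c1OC` departs from compound 1 by one small change: hydrogen in place of fluoro on an aromatic carbon. Among the compounds with values here, the only measured step, a 30-fold lower number from compound 1 to compound 2 (1.48 log units; beyond the scatter) (1H-indol-3-yl in place of 4-fluorophenyl), is large but replaces the whole group, so it says little about the fluoro alone. Within the data shown here, no measured pair isolates that atom, so no step beyond the scatter is expected in this assay here. The expected step is a 1.2-fold lower number from compound 1 to compound 4 (0.07 log units; within the scatter) and stays within the scatter. For compound 4 the estimate is 5000 nM, with an expected range from 2000 nM to 12000 nM.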

Compound 4, half-maximal inhibitory concentration: 458 nM
Compound 4: middle estimate off by 11-fold (1.04 log units), on the high side; measured number below the stated range.
By their numbers in this assay, from the lowest: compound 2; then compound 4; then compounds 3 and 1 (each within the scatter of the next).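

In this assay the single fluoro on the aromatic carbon proves to matter on its own: hydrogen in its place gives a 13-fold lower number from compound 1 to compound 4 (1.11 log units; beyond the scatter), which the whole-group step could not show. Phenyl in place of 1H-indol-3-yl gives a 2.3-fold higher number from compound 2 to compound 4 (0.37 log units; beyond the scatter), so compound 4 stands much nearer to compound 2 than compound 1 does, and much of that earlier gap goes with the fluoro alone. Nothing at hand explains this step.

The compounds shown leave open how a chloro group or an amine at this place would compare with hydrogen and fluoro. They also leave open whether the same change would shift compound 3 as well.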